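Swapping a lactam for a pyridinylamine: expected solubility

A few compounds are considered here, and "the series" means these few. Any claim that something is new, unique, unknown or untested is made for them only; others in the source may bear on it.

Measured so far:
Compound 1, `Cc1ncccc1-c1cnc(NCc2c(F)ccc3c2CCO3)c2ncc(=O)[nH]c12`: 29000 nM
Compound 2, `CC1(C)CC(=O)N(c2cnc(NCc3c(F)ccc4c3CCO4)n3cnnc23)C1`: 57000 nM

Of the compounds shown here, two have been tested in a physicochemical assay for solubility, read by LC-MS, in phosphate buffer, with a stated time of 24 h, at pH 7.4; a higher number here means a more soluble compound, a lower number a less soluble compound. Compound 1 gives 29000 nM in this assay, and compound 2 gives 57000 nM. The two numbers lie within the scatter of each other, so neither can be called more soluble than the other; compound 2 simply has the larger of the two numbers.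

Compound 3, `CN(c1cccnc1)c1cnc(NCc2c(F)ccc3c2CCO3)n2cnnc12`, has not been measured. It differs from compound 2 in a single place: methyl(pyridin-3-yl)amino in place of 4,4-dimethyl-2-oxopyrrolidin-1-yl on an aromatic carbon. The group that leaves carries a carbonyl within a non-aromatic ring, while the group that enters brings an aromatic ring and two hydrogen-bond acceptors.

Among the measured compounds shown here, no step between two measured compounds is recorded here, so there is no directly comparable change to lean on. The only aromatic-bearing reference, compound 1, gives 29000 nM in this assay. On that basis a modest downward step is expected from compound 2 to compound 3, a 2.3-fold lower number from compound 2 to compound 3 (0.36 log units; beyond the scatter), close to the edge of the scatter. Compound 3 is therefore estimated at 25000 nM in this assay, with a likely range from 8000 nM to 80000 nM.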

Compound 3, solubility: 47000 nM
Compound 3: middle estimate off by 1.9-fold (0.27 log units), on the low side, within the range that was stated.
By their numbers in this assay, from the lowest: compounds 1, 3 and 2 (each within the scatter of the next).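

In this assay the swap of 4,4-dimethyl-2-oxopyrrolidin-1-yl for methyl(pyridin-3-yl)amino gives a 1.2-fold lower number from compound 2 to compound 3 (0.08 log units; within the scatter) and so the two groups cannot be told apart by this read-out. Among the compounds shown here, this is the first comparison in which only this position differs, on the aromatic carbon para to a large group, and it shows that a five-membered non-aromatic ring carrying a carbonyl and a six-membered aromatic ring, quite different groups on paper, can stand here with readings that lie within the scatter of each other. Nothing measured here speaks to what lies behind this result.

This single pair shows only how these two groups compare, and compound 1 differs from compound 2 and compound 3 in more than one place, so it adds nothing about this position. Still open, on these data alone, is whether another kind of group on the same aromatic carbon, such as a carboxylic acid or a simple primary amine, would stay within the scatter of compound 2 in this assay or move beyond it.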